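Benzyl variation on the compound 2 scaffold

A few compounds are considered here, and "the series" means these few. Any claim that something is new, unique, unknown or untested is made for them only; others in the source may bear on it.

Measured so far in a functional assay on HCT-116 cells (Homo sapiens) for inhibition, read by MTT assay, with a stated time of 72 h; on this read-out lower numbers stand for stronger inhibition and higher numbers for weaker inhibition:
compound 1 `Nc1ccc(-c2ccc3c(c2)oc(=O)n3Cc2ccc(F)cc2)cn1` gives 16500 nM
compound 2 `O=c1oc2cc(-c3cnc4[nH]ccc4c3)ccc2n1Cc1ccc(F)cc1` gives 5990 nM

Among the compounds with values here, compound 2 holds the lowest number of the two; the single measured step, a 2.8-fold lower number from compound 1 to compound 2 (0.44 log units; beyond the scatter), sits on an aromatic carbon and does not touch the benzyl group. Compound 3 `Cc1cccc(Cn2c(=O)oc3cc(-c4cnc5[nH]ccc5c4)ccc32)c1` differs from compound 2 by 3-methylphenyl in place of 4-fluorophenyl on a saturated chain carbon bound to an aromatic nitrogen, 4-fluorobenzyl to 3-methylbenzyl. Within the data shown here, no measured step bears on this change, so compound 3 is expected to stay near compound 2 with a step of a 1.0-fold higher number from compound 2 to compound 3 (0.00 log units; within the scatter) in this assay, not clearly beyond the scatter. The estimate for compound 3 is 6000 nM, range 2500 nM to 15000 nM.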

Compound 3, half-maximal inhibitory concentration: 5120 nM
Compound 3: middle estimate off by 1.2-fold (0.07 log units), on the high side; the measured number falls inside the stated range.
By their numbers in this assay, from the lowest: compounds 3 and 2 (each within the scatter of the next); then compound 1.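

In this assay, within the data shown here, the change from 4-fluorobenzyl to 3-methylbenzyl reads a 1.2-fold lower number from compound 2 to compound 3 (0.07 log units; within the scatter) and gives the first look at the group on the aromatic nitrogen. Compound 2 and compound 3 cannot be ranked, so this position tolerates this exchange of phenyl substituents without a readable shift. No supporting data bear on this result.

Still open, going by these compounds, is whether any group at this position moves the number beyond the scatter. A carboxylic acid or an amine on the phenyl ring, or a longer chain in place of the benzyl carbon, would test that.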